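The source may hold more compounds than are shown below. What is called first, only, known or untested is meant among the compounds shown, and "the series" means these compounds.

Measured compounds:
- Compound 1, `Cc1nnc(SCC(=O)N/N=c2/scc(-c3ccc(F)cc3)n2-c2ccccc2)s1`: 27.3 ug/mL
- Compound 2, `Cn1nnnc1SCC(=O)N/N=c1/scc(-c2ccc(F)cc2)n1-c1ccccc1`: "not determined" (no result reported)

The study looks at cytotoxicity toward a rat glioma cell line, followed in a functional assay on C6 cells (Rattus norvegicus) for cytotoxicity, read by MTT assay, with a stated time of 24 h; on this read-out lower numbers stand for stronger inhibition and higher numbers for weaker inhibition. Among the measured compounds shown here, compound 1 gives 27.3 ug/mL in this assay, and that is the only number available. For compound 2 this assay records "not determined" (no result reported), so there is no number at all to place it on: its position relative to compound 1 is simply unknown.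

The next compound, compound 3, `O=C(CSc1nnnn1-c1ccccc1)N/N=c1/scc(-c2ccc(F)cc2)n1-c1ccccc1`, differs from compound 2 by a single change: phenyl in place of methyl on an aromatic nitrogen — in words, phenyl in place of methyl on an aromatic nitrogen. For the measured compounds named here, no pair of measured compounds shows how such a change plays out in this assay, so no measured step can be cited for it. Going by the values given here, the expectation therefore rests only on compound 1, the one compound with a number, and on the fact that the change is a modest one at the edge of the molecule rather than in its shared core. Any shift from the unknown value of compound 2 is expected to be small, of a size not beyond the usual scatter, with no direction favoured.

Compound 3 is accordingly estimated at 30 ug/mL in this assay, within a range of 8 ug/mL to 120 ug/mL.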

Compound 3, half-maximal inhibitory concentration: 24.3 ug/mL
For compound 3 the middle estimate is 1.2-fold (0.09 log units) above the measured one; the measured number falls inside the stated range.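

Among the compounds shown here, compound 3 gives the first measured comparison at the sulfur: in this assay, replacing 5-methyl-1,3,4-thiadiazol-2-yl with 1-phenyl-1H-tetrazol-5-yl gives a 1.1-fold lower number from compound 1 to compound 3 (0.05 log units; within the scatter) and so stays within the scatter of repeated measurements. At this level of resolution, the two groups on the sulfur cannot be told apart, even though they differ in their ring and in what that ring carries. The step from methyl to phenyl on the aromatic nitrogen cannot be read, since compound 2 has no number, and no measurement given here explains the closeness of compound 1 and compound 3.

On these data alone, the effect of the tetrazole substituent alone therefore remains open, including whether a small methyl and a larger phenyl on that nitrogen would give similar numbers in this assay or clearly different ones. It is also unknown how this read-out would respond to a longer chain such as n-butyl on the same nitrogen, or to an amine or a carboxylic acid attached to the phenyl ring of the 1-phenyl-1H-tetrazol-5-yl group.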